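Taking the Phenyl Group Off Compound 3

This account rests on a few compounds, and the source may have more. Where it says the series, first, only, none or still open, it means among the compounds named here.

Three compounds that differ only in the length of their chain have been measured so far. In a functional assay on A549 cells (Homo sapiens) for antiproliferative activity, read by MTT assay, with a stated time of 48 h (on this read-out higher numbers stand for weaker inhibition of growth and lower numbers for stronger inhibition of growth), compound 1 `CCOc1cc(NC(=O)CCCCCC(=O)Nc2cc(-c3ccccc3)ccc2N)cc2c1OCC([N+](=O)[O-])=C2` gives 4860 nM, compound 2 `CCOc1cc(NC(=O)CCCCC(=O)Nc2cc(-c3ccccc3)ccc2N)cc2c1OCC([N+](=O)[O-])=C2` gives 7460 nM, and compound 3 `CCOc1cc(NC(=O)CCCCCCC(=O)Nc2cc(-c3ccccc3)ccc2N)cc2c1OCC([N+](=O)[O-])=C2` gives 5400 nM. Compound 3 lies within the usual scatter of both other compounds, so these three results cannot be told apart.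

Compound 4 `CCOc1cc(NC(=O)CCCCCCC(=O)Nc2ccccc2N)cc2c1OCC([N+](=O)[O-])=C2` keeps the chain of compound 3 but changes the other end of the molecule: hydrogen in place of phenyl on an aromatic carbon. Hydrogen takes the place of phenyl on an aromatic carbon, para to an amino group. Going by the values given here, no measured pair of compounds shows what this exchange does, so the data offer no direction for it, and any forecast must stay cautious.

In this assay, the expected change is none beyond the scatter, and the estimated step is a 1.1-fold lower number from compound 3 to compound 4 (0.03 log units; within the scatter). The estimate for compound 4 is 5000 nM, with an expected range from 1800 nM to 14000 nM.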

Compound 4, concentration for 50% growth inhibition: 11700 nM
Compound 4: the middle estimate sits 2.3-fold (0.37 log units) below what was measured; low and high end bracket the measured number.
By their numbers in this assay, from the lowest: compounds 1, 3, 2 and 4 (each within the scatter of the next, the first and the last beyond it).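

In this assay, putting hydrogen in place of phenyl on this aromatic carbon, para to an amino group, gives a 2.2-fold higher number from compound 3 to compound 4 (0.34 log units; beyond the scatter). Growth inhibition therefore weakens modestly when the phenyl group is removed, giving the first sign that this position affects the result, as the earlier compounds all carried phenyl there. Nothing available explains the loss, so the data cannot say what the phenyl group contributes.

The compounds shown leave open whether the same exchange would have a similar effect on the shorter chains of compound 1 and compound 2. They also leave open whether a smaller group at this position, such as methyl or a chlorine atom, or another ring, such as thiophene, would behave more like phenyl or more like hydrogen.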